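Swapping the Sulfonyl Aryl Group in an EP3 Antagonist Series

The source may report more compounds than this note shows. Statements on the series, on what has been measured and on what is new or still open speak of the compounds shown alone.

Compound 1, `O=C(NC/C=C1\CCCc2cnn(-c3ccc(C(F)(F)F)cc3)c21)NS(=O)(=O)c1cc(Cl)c(Cl)s1`: 0.4 nM
Compound 2, `Cc1ncc(S(=O)(=O)NC(=O)NC/C=C2\CCCc3cnn(Cc4ccc(Cl)cc4Cl)c32)s1`: 7 nM
Compound 3, `O=C(NC/C(F)=C1\CCCc2cnn(C3CCN(c4ccc(F)cc4)CC3)c21)NS(=O)(=O)c1cc(Cl)c(Cl)s1`: 13 nM

These three compounds share a core and were tested in an assay on isolated protein for displacement of a labelled ligand from prostaglandin E2 receptor EP3 subtype (Homo sapiens), read by scintillation counting, with a stated time of 2 h; a lower number here means a stronger inhibitor, a higher number a weaker inhibitor. Compound 2 gives 7 nM, the second highest of the three numbers; compound 3, with 13 nM, lies within the scatter of it, whereas compound 1 at 0.4 nM sits well below, beyond the scatter. Compound 4, `COc1ccccc1S(=O)(=O)NC(=O)NC/C=C1\CCCc2cnn(Cc3ccc(Cl)cc3Cl)c21`, has not been measured. It differs from compound 2 in one place: 2-methoxyphenyl in place of 2-methyl-1,3-thiazol-5-yl on a sulfonyl sulfur. Going by the values given here, no measured pair shows this change, so its effect is not known from these numbers. A modest weakening is expected, near the edge of the scatter, the expected step being a 2.1-fold higher number from compound 2 to compound 4 (0.33 log units; beyond the scatter). Compound 4 is therefore estimated to give 15 nM in this assay, within a range from 3 nM to 70 nM.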

Compound 4, inhibition constant: 62 nM
Beside the measured number, compound 4's estimate is 4.1-fold (0.62 log units) below it; the range from low to high includes it.
By their numbers in this assay, from the lowest: compound 1; then compounds 2 and 3 (each within the scatter of the next); then compound 4.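

On the sulfonyl sulfur, the choice of aromatic ring clearly matters: in this assay the swap to 2-methoxyphenyl gives an 8.9-fold higher number from compound 2 to compound 4 (0.95 log units; beyond the scatter) and this step lies beyond the scatter. The earlier compounds shown here differ from one another in more than one place, so none of them could isolate this position. Nothing measured here says why the number rises.

Still open, as far as these compounds go, is how a plain phenyl or a pyridine ring on the same sulfur would compare. From the compounds shown here alone, it is also open whether this change would have a similar effect on the core of compound 1.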